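The source may hold more compounds than are shown below. What is called first, only, known or untested is meant among the compounds shown, and "the series" means these compounds.

The three measured compounds share one core and differ in the ring-bearing group on a saturated chain carbon bound to an amine nitrogen. In a functional assay on the whole organism with Rattus norvegicus as the target (on this read-out lower numbers stand for an effect already at smaller amounts and higher numbers for an effect only at larger amounts of compound), compound 1 `CCN(CCNC(=O)c1cc(Cl)c(N)cc1OC)Cc1ccccn1` gives 30 mg/kg, compound 2 `CCN(CCNC(=O)c1cc(Cl)c(N)cc1OC)Cc1ccccc1Cl` gives 10 mg/kg and compound 3 `CCN(CCNC(=O)c1cc(Cl)c(N)cc1OC)Cc1ccc(Cl)cc1` gives 0.24 mg/kg, the lowest number of the three.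

Compound 4 `CCN(CCNC(=O)c1cc(Cl)c(N)cc1OC)Cc1ccc(Cl)cc1Cl` takes chloro in place of hydrogen on an aromatic carbon of compound 3: chloro in place of hydrogen on an aromatic carbon. The new chloro sits ortho to a large group and meta to a chloro group, turning 4-chlorophenyl into 2,4-dichlorophenyl.

Going by the values given here, the steps that bear on this are a 42-fold lower number from compound 2 to compound 3 (1.62 log units; beyond the scatter), which is large, a 130-fold lower number from compound 1 to compound 3 (2.10 log units; beyond the scatter), also large, and a 3.0-fold lower number from compound 1 to compound 2 (0.48 log units; beyond the scatter), which is modest. No measured pair adds a second chloro to a chlorinated ring, so the effect of this change is not shown directly. Compound 4 keeps the 4-chlorophenyl pattern of compound 3 at 0.24 mg/kg but also shares the 2-chlorophenyl pattern of compound 2 at 10 mg/kg. A modest step towards a higher number is therefore expected in this assay, well short of the large gap between those two compounds. The estimated change is a 4.2-fold higher number from compound 3 to compound 4 (0.62 log units; beyond the scatter). The expected value for compound 4 is 1 mg/kg, with an estimated range of 0.2 mg/kg to 6 mg/kg.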

Compound 4, dose for half-maximal effect: 10 mg/kg
The estimate for compound 4 lay 10-fold (1.00 log units) below the measured number, outside the stated range (above it).
By their numbers in this assay, from the lowest: compound 3; then compounds 2 and 4 (each within the scatter of the next); then compound 1.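

In this assay, chloro in place of hydrogen ortho to a large group on the 4-chlorophenyl ring gives a 42-fold higher number from compound 3 to compound 4 (1.62 log units; beyond the scatter), so the 4-chlorophenyl pattern does not keep its low number once this place is filled. Read from the other side, 2,4-dichlorophenyl in place of 2-chlorophenyl gives no change at the digits printed from compound 2 to compound 4 (within the scatter), so the two compounds with chloro ortho to a large group cannot be told apart, whether or not the 4-chloro is present. Against pyridin-2-yl, 2,4-dichlorophenyl gives only a 3.0-fold lower number from compound 1 to compound 4 (0.48 log units; beyond the scatter), which leaves compound 3 alone at the low end of the four compounds.

No data on the series explain the rise at this position. From the compounds shown here alone, it remains open whether a fluoro, a methyl or a methoxy group ortho to a large group would raise the number as far as chloro does, or whether the rise is specific to chloro at this place on the 4-chlorophenyl ring.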